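Taking the fluoro group off compound 1

The source may hold more compounds than are shown below. What is called first, only, known or untested is meant among the compounds shown, and "the series" means these compounds.

In a functional assay on SiHa cells (Homo sapiens) for inhibition, read by CCK-8 assay, with a stated time of 72 h, tested at 10 uM (on this read-out lower numbers stand for less inhibition of growth and higher numbers for more inhibition of growth at the one concentration tested), compound 1 `CN(C)C(=O)c1cc2cnc(Nc3ccc(NC(=O)C4(C(=O)Nc5ccccc5F)CC4)cc3)nc2n1C1CCCC1` gives 103%. Compound 2 `CN(C)C(=O)c1cc2cnc(Nc3ccc(NC(=O)C4(C(=O)Nc5ccc(Br)cc5)CC4)cc3)nc2n1C1CCCC1` gives 98.8%, which lies within the scatter of the first value. The core of compound 1 is absent from compound 3 `Nc1ccc(NC(=O)C2(C(=O)Nc3ccc(F)cc3)CC2)cc1F`, and compound 3 gives 36%, far lower and beyond the scatter.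

Compound 4 `CN(C)C(=O)c1cc2cnc(Nc3ccc(NC(=O)C4(C(=O)Nc5ccccc5)CC4)cc3)nc2n1C1CCCC1` keeps everything in compound 1 except one atom: hydrogen in place of fluoro on an aromatic carbon. Hydrogen stands in place of fluoro on an aromatic carbon, ortho to a large group, turning 2-fluorophenyl into phenyl. For the measured compounds named here, one measured step bears on this same aryl group, the exchange of 2-fluorophenyl for 4-bromophenyl. That step is a number 4.2 percentage points lower from compound 1 to compound 2 (within the scatter), so a larger change on this group left the read-out within the scatter. Compound 3 differs in too many places to serve as a guide. No direct measurement of the fluoro group's removal exists yet. The step of a number 5 percentage points lower from compound 1 to compound 4 (within the scatter) is therefore expected to stay within the scatter, with no clear direction. Compound 4 is estimated at 98%, with an expected range of 86% to 108%.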

Compound 4, percent growth inhibition at one concentration: 106%
Compound 4: the middle estimate sits 8 percentage points below what was measured; measured number inside the range.
By their numbers in this assay, from the lowest: compound 3; then compounds 2, 1 and 4 (each within the scatter of the next).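

In this assay, the plain phenyl of compound 4 shows that the fluoro group is not needed to hold this read-out, with hydrogen in its place giving a number 3 percentage points higher from compound 1 to compound 4 (within the scatter) at the one concentration tested. The exchange of bromo for hydrogen gives a number 7.2 percentage points higher from compound 2 to compound 4 (within the scatter) and so adds the unsubstituted ring to the two halogen-bearing compounds, with no separation among the three on this aryl group. Nothing given here explains why these changes leave the read-out within the scatter.

What remains open is whether an amine or a carboxylic acid on this phenyl ring would also stay within the scatter of these compounds. Testing at this single concentration also leaves open whether compounds 1, 2 and 4 would separate at lower concentrations.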